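The source may report more compounds than this note shows. Statements on the series, on what has been measured and on what is new or still open speak of the compounds shown alone.

Among the compounds with values here, compound 2 `O=c1ccoc2cc(OCc3cn(Cc4ccc(F)cc4)nn3)ccc12` is the only compound in this set with a full number in a functional assay on HeLa cells (Homo sapiens) for cytotoxicity, read by MTT assay, with a stated time of 48 h; a lower number here means a stronger inhibitor, a higher number a weaker inhibitor: compound 2 gives 12000 nM. Within the data shown here, compound 1 `Cc1cccc(Cn2cc(COc3ccc4c(=O)ccoc4c3)nn2)c1` is reported in this assay only as a limit, > 100000 nM, and the single measured step is therefore also read against that limit (the limit of > 100000 nM in this assay, at which 1 of the 2 values shown sits). That step, an at least 8.3-fold lower number from compound 1 to compound 2 (0.92 log units; beyond the scatter), comes with the 4-fluorophenyl in place of 3-methylphenyl on the saturated chain carbon bound to the aromatic nitrogen.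

Compound 3 `O=c1ccoc2cc(OCc3cn(Cc4ccccc4Cl)nn3)ccc12` carries a further change at the same place: 2-chlorophenyl in place of 4-fluorophenyl on a saturated chain carbon bound to an aromatic nitrogen. Among the measured compounds shown here, the one measured step concerns a different pair of groups, so it bears on this change only loosely; a halogenated phenyl remains, and no measured step tells how moving it to the 2-position affects this assay. Compound 3 is therefore expected to stay close to compound 2, with a step of a 1.3-fold higher number from compound 2 to compound 3 (0.12 log units; within the scatter) at most within or just beyond the scatter. The estimate for compound 3 is 16000 nM, within a range from 5000 nM to 60000 nM.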

Compound 3, half-maximal inhibitory concentration: > 100000 nM
Compound 3 ended at the assay's limit; the forecaster's own chance of this, stated with the estimate: 20%; middle value at least 6.2-fold (0.79 log units) away from the limit.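

At this position, on a saturated chain carbon bound to an aromatic nitrogen, a halogenated phenyl does not by itself keep a full number in this assay: 2-chlorophenyl in place of 4-fluorophenyl gives an at least 8.3-fold higher number from compound 2 to compound 3 (0.92 log units; beyond the scatter). Compound 3 is reported in this assay only as a limit, > 100000 nM. Among the groups shown, only 4-fluorophenyl gives a full number, the step between the two limit compounds cannot be read, and the set now stands largely at the edge of what the assay reports: the limit of > 100000 nM in this assay, at which 2 of the 3 values shown sit.

In this step the halogen and its place on the ring change together, and the compounds shown do not separate the two. They also leave open how this position would read with a plain phenyl, or with an amine or a carboxylic acid on the ring.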